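The source may report more compounds than this note shows. Statements on the series, on what has been measured and on what is new or still open speak of the compounds shown alone.

Within the data shown here, in a functional assay on HeLa cells (Homo sapiens) for inhibition, read by sulforhodamine B assay, with a stated time of 48 h (a higher number here means a weaker inhibitor of growth, a lower number a stronger inhibitor of growth), two compounds have numbers so far. Compound 1 `Oc1ccc(-c2nc3ncccn3c2CN2CCCCC2)cc1` gives 4030 nM, and compound 2 `c1ccc(-c2nc3ncccn3c2CN2CCCC2)cc1` gives 70 nM. Compound 2 therefore holds the lower of the two numbers, and its gap to compound 1 lies beyond the usual scatter. Compound 3 `c1ccc(-c2nc3ncccn3c2CN2CCCCC2)cc1` has not yet been measured. It differs from compound 2 in one place: piperidin-1-yl in place of pyrrolidin-1-yl on a saturated chain carbon bound to an aromatic carbon, with piperidin-1-yl in place of pyrrolidin-1-yl on a saturated chain carbon bound to an aromatic carbon. Among the measured compounds shown here, no measured pair shows this change on its own, so the data give no direct guide to its size. A small rise in the number is expected, near the edge of the scatter, and the expected step is a 2.1-fold higher number from compound 2 to compound 3 (0.33 log units; beyond the scatter). The estimate for compound 3 is 150 nM, with an expected range from 40 nM to 700 nM.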

Compound 3, concentration for 50% growth inhibition: 2280 nM
Beside the measured number, compound 3's estimate is 15-fold (1.18 log units) below it; measured number outside the range, above it.
By their numbers in this assay, from the lowest: compound 2; then compounds 3 and 1 (each within the scatter of the next).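

In this assay the amine on the saturated chain carbon bound to an aromatic carbon proves to be a sensitive point in this series: piperidin-1-yl in place of pyrrolidin-1-yl gives a large step (a 33-fold higher number from compound 2 to compound 3 (1.51 log units; beyond the scatter)). With piperidin-1-yl held constant, hydrogen in place of hydroxy on an aromatic carbon (a 1.8-fold lower number from compound 1 to compound 3 (0.25 log units; within the scatter)) stays within the scatter, so this pair shows no clear effect of the hydroxy group. Nothing available explains why the amine change has so large an effect. As far as these compounds go, whether the step follows ring size or is particular to these two rings remains open, and azepan-1-yl, morpholin-4-yl or dimethylamino on the same carbon would bear on that. Also open, from the compounds shown here alone, is whether hydroxy would matter alongside pyrrolidin-1-yl.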